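This account rests on a few compounds, and the source may have more. Where it says the series, first, only, none or still open, it means among the compounds named here.

Compound 3 `CC/C(=C(/c1ccc(/C=C/C(=O)O)cc1)c1ccc2[nH]nc(C)c2c1)c1ccccc1` is one of three compounds that share a core in which a central double bond carries an acrylic acid arm on one side. In a functional assay on MCF7 cells (Homo sapiens) for cytotoxicity, read by CellTiter-Glo, with a stated time of 5 days (a higher number here means a weaker inhibitor, a lower number a stronger inhibitor), compound 3 gives > 1000 nM, which is a limit of the assay and not a number. Compound 1 `O=C(O)/C=C/c1ccc(/C(=C(/CCO)c2ccccc2)c2ccc3[nH]ncc3c2)cc1` likewise gives only a limit in this assay, > 1000 nM. Going by the values given here, the one compound with a real number is compound 2 `O=C(O)/C=C/c1ccc(/C(=C(\c2ccccc2)C2CCCCC2)c2ccc3[nH]ncc3c2)cc1`, which gives 64 nM in this assay. Among the compounds with values here, the single measured step between neighbours, an at least 15-fold lower number from compound 1 to compound 2 (1.19 log units; beyond the scatter), is the only place where a value moves away from the limit of > 1000 nM in this assay, at which 2 of the 3 values shown sit, and it concerns a partner on the chain carbon, not the indazole.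

Compound 4 `CC/C(=C(/c1ccc(/C=C/C(=O)O)cc1)c1ccc2[nH]ncc2c1Cl)c1ccccc1` differs from compound 3 in one place: 4-chloro-1H-indazol-5-yl in place of 3-methyl-1H-indazol-5-yl on a double-bonded chain carbon bound to an aromatic carbon and a double-bonded chain carbon. No measured step touches the indazole partner at all, so nothing among the shown numbers says how this change should move the result in this assay. Compound 3 sits at a limit, so even its starting point is open. The expected step is a number no higher from compound 3 to compound 4 (the limit leaves the size open), meaning no change that can be told from the scatter. Compound 4 is therefore estimated at 1000 nM, with a range from 150 nM to 5000 nM in this assay, and a sizeable chance that only a limit is reported again.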

Compound 4, half-maximal inhibitory concentration: 1.6 nM
Compound 4: middle estimate off by 630-fold (2.80 log units), on the high side; measured number below the stated range.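

Going by these compounds alone, until now only the partner on the chain carbon had moved a value away from the limit, so compound 4 is the first sign that the indazole partner can also decide the result. In this assay, 4-chloro-1H-indazol-5-yl in place of 3-methyl-1H-indazol-5-yl gives an at least 620-fold lower number from compound 3 to compound 4 (2.79 log units; beyond the scatter), even though the two groups have the same heavy-atom count and the same rings. This step is only a minimum, as its starting point, compound 3, sits at a limit and not at a number: the limit of > 1000 nM in this assay, at which 2 of the 4 values shown sit.

The swap changes two things at once, since the methyl group leaves and the chlorine enters, and the compounds shown cannot separate these two parts; an indazole carrying neither group on the core of compound 3 would be needed to tell whether losing the methyl, gaining the chlorine or both accounts for the step. As far as these compounds go, it also remains open whether the chlorine itself is needed or whether a fluorine, a bromine or a nitrile in its place would give a similar result.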